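A few compounds are considered here, and "the series" means these few. Any claim that something is new, unique, unknown or untested is made for them only; others in the source may bear on it.

In an ADME assay on MT2 cells (Homo sapiens) for cytotoxicity (on this read-out higher numbers stand for lower toxicity in this test and lower numbers for higher toxicity in this test), compound 1 `CCc1cc(CNC(=O)c2cc3nc(C)c([C@H](OC(C)(C)C)C(=O)O)c(-c4cc(F)c5c(c4C)CCCO5)n3n2)ccc1F` gives > 40000 nM, a limit of the assay rather than a number.
Compound 2 `Cc1nc2cc(C(=O)NCc3ccc(F)cc3S(C)(=O)=O)nn2c(-c2cc(F)c3c(c2C)CCCO3)c1[C@H](OC(C)(C)C)C(=O)O` gives > 40000 nM, again a limit.
Compound 3 `Cc1nc2cc(C(=O)NCC3CCCCC3)nn2c(-c2cc(F)c3c(c2C)CCCO3)c1[C@H](OC(C)(C)C)C(=O)O` gives > 40000 nM, also a limit.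

Compound 3 thus stands at the limit of > 40000 nM in this assay, at which 3 of the 3 values shown sit. The measured steps a step that the two limits leave unreadable from compound 1 to compound 3, a step that the two limits leave unreadable from compound 2 to compound 3 and a step that the two limits leave unreadable from compound 1 to compound 2 cannot be sized because the limit of > 40000 nM in this assay, at which 3 of the 3 values shown sit, holds both ends of each. Compound 4 `Cc1nc2cc(C(=O)NCC3CCOCC3)nn2c(-c2cc(F)c3c(c2C)CCCO3)c1[C@H](OC(C)(C)C)C(=O)O` differs from compound 3 by oxan-4-yl in place of cyclohexyl on a saturated chain carbon bound to an amide-type nitrogen. Compounds 1, 2 and 3 all rest at the limit of > 40000 nM in this assay, at which 3 of the 3 values shown sit, so for compound 4 a step of a number no higher from compound 3 to compound 4 (the limit leaves the size open) is expected, meaning no change that could be read. Compound 4 is accordingly estimated at 40000 nM, within 20000 nM to 80000 nM, and will most likely be reported as a limit once more.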

Compound 4, half-maximal cytotoxic concentration: > 40000 nM
Compound 4: no number, only a limit (the forecaster's own chance of this, stated with the estimate: 80%); the middle value lies on the limit itself.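

Compound 4 also gives only a limit in this assay, so its steps from compound 1, compound 2 and compound 3 cannot be read: the limit of > 40000 nM in this assay, at which 4 of the 4 values shown sit. As far as these compounds go, whether changing the group on the amide nitrogen alters the result at all remains open for these four compounds.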